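A Hydroxyphenyl Ketone Enters the Series

This account rests on a few compounds, and the source may have more. Where it says the series, first, only, none or still open, it means among the compounds named here.

Three compounds share one core and differ only in the aryl group on the carbonyl. Compound 1 `COc1cc(-c2nnc3n2NC(c2ccco2)C(C(=O)c2ccccc2F)S3)cc(OC)c1OC`, compound 2 `COc1cc(-c2nnc3n2NC(c2ccco2)C(C(=O)c2ccc(Br)cc2)S3)cc(OC)c1OC` and compound 3 `COc1cc(-c2nnc3n2NC(c2ccco2)C(C(=O)c2ccc(F)c(F)c2)S3)cc(OC)c1OC` were tested in a functional assay on A549 cells (Homo sapiens) for cytotoxicity, read by MTT assay, with a stated time of 48 h (on this read-out higher numbers stand for weaker inhibition and lower numbers for stronger inhibition), where compound 1 gives 78700 nM, compound 2 gives 42100 nM and compound 3 gives 93700 nM, the highest of the three numbers. Compound 4 `COc1cc(-c2nnc3n2NC(c2ccco2)C(C(=O)c2ccc(O)cc2)S3)cc(OC)c1OC` is unmeasured; it arises from compound 3 by 4-hydroxyphenyl in place of 3,4-difluorophenyl on a carbonyl carbon. The two measured swaps of the aryl group that end at compound 3, a 1.2-fold higher number from compound 1 to compound 3 (0.08 log units; within the scatter) and a 2.2-fold higher number from compound 2 to compound 3 (0.35 log units; beyond the scatter), moved the numbers little, so compound 4 is expected to show only a small step, a 1.3-fold lower number from compound 3 to compound 4 (0.13 log units; within the scatter), with no clear direction beyond the scatter. The estimate for compound 4 in this assay is 70000 nM, within 25000 nM to 200000 nM.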

Compound 4, half-maximal inhibitory concentration: 93400 nM
Compound 4: middle estimate off by 1.3-fold (0.13 log units), on the low side; low and high end bracket the measured number.
By their numbers in this assay, from the lowest: compounds 2, 1, 4 and 3 (each within the scatter of the next, the first and the last beyond it).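

In this assay, going by these compounds alone, the first aryl group here with a hydrogen-bond donor gives a 1.0-fold lower number from compound 3 to compound 4 (0.00 log units; within the scatter), so at this carbonyl carbon the exchange of two fluorines for a hydroxy leaves the read-out unchanged within the scatter. The comparison with 2-fluorophenyl gives a 1.2-fold higher number from compound 1 to compound 4 (0.07 log units; within the scatter), also within the scatter, whereas hydroxy in place of bromo gives a 2.2-fold higher number from compound 2 to compound 4 (0.35 log units; beyond the scatter), a modest step beyond it. Nothing available explains these numbers. On these data alone, what an amine or a carboxylic acid in place of the hydroxy would do remains open, as does whether any aryl group at this position can reach much lower numbers.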